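Swapping an Amide Arm for an Aromatic Ester

The source may hold more compounds than are shown below. What is called first, only, known or untested is meant among the compounds shown, and "the series" means these compounds.

Among the measured compounds shown here, compound 1 `N#Cc1c(N)nc(SCC(=O)NCO)c(C#N)c1-c1ccc(OCC2CC2)cc1` has the higher of the two numbers measured so far. In a functional assay on CHO cells for agonist activity at adenosine receptor A2b (Homo sapiens), read by AlphaScreen and cAMP accumulation (on this read-out lower numbers stand for an effect already at smaller amounts and higher numbers for an effect only at larger amounts of compound), compound 1 gives 182 nM, while compound 2 `CCOc1ccc(-c2c(C#N)c(N)nc(SCc3ncc[nH]3)c2C#N)cc1` gives 11.7 nM, a gap well beyond the usual scatter, showing that much lower numbers are reachable in this series. Compound 3 `COC(=O)c1cccc(CSc2nc(N)c(C#N)c(-c3ccc(OCC4CC4)cc3)c2C#N)c1` has not yet been measured. It differs from compound 1 in one place: 3-(methoxycarbonyl)phenyl in place of (hydroxymethyl)carbamoyl on a saturated chain carbon bound to a sulfur. For the measured compounds named here, no measured pair shows this exact change, so its size is uncertain; the step expected here, a 3.0-fold lower number from compound 1 to compound 3 (0.48 log units; beyond the scatter), is a moderate move toward a lower number. Compound 3 is estimated at 60 nM, within 15 nM to 250 nM.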

Compound 3, half-maximal effective concentration: 347 nM
Beside the measured number, compound 3's estimate is 5.8-fold (0.76 log units) below it; measured number outside the range, above it.
By their numbers in this assay, from the lowest: compound 2; then compounds 1 and 3 (each within the scatter of the next).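

In this assay the swap gives a 1.9-fold higher number from compound 1 to compound 3 (0.28 log units; within the scatter) and so shows that this saturated chain carbon bound to a sulfur accepts a much larger group, with an aromatic ring and no hydrogen-bond donors, without a change beyond the scatter. Nothing measured here explains why the two groups read alike. From the compounds shown here alone, the swap alters several features at once, so their separate contributions remain unknown. Also open, going by these compounds, is whether a plain phenyl ring, or a carboxylic acid in place of the methoxycarbonyl group, would move the number.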